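The source may hold more compounds than are shown below. What is called first, only, known or untested is meant among the compounds shown, and "the series" means these compounds.

The measured compounds:
Compound 1 `COc1cc2c(cc1N1C[C@@H](C)N(C)[C@@H](C)C1)N(C(=O)c1ccc(-c3cccc(C)n3)c3ccccc13)CC2` gives 100 nM in an assay on isolated protein for binding affinity to 5-hydroxytryptamine receptor 1D (Homo sapiens); a higher number here means a weaker inhibitor, a lower number a stronger inhibitor.
Compound 2 `COc1cc2c(cc1N1C[C@@H](C)N[C@@H](C)C1)N(C(=O)c1ccc(-c3cccc(C)n3)c3ccccc13)CC2` gives 126 nM in this assay.
Compound 3 `CCN1[C@H](C)CN(c2cc3c(cc2OC)CCN3C(=O)c2ccc(-c3cccc(C)n3)c3ccccc23)C[C@@H]1C` gives 126 nM in this assay.

Compound 3 stands level with compound 2 at the digits shown, and together the two hold the highest of the three numbers; the step of a 1.3-fold higher number from compound 1 to compound 3 (0.10 log units; within the scatter) lies within the scatter, as does no change at the digits printed from compound 2 to compound 3 (within the scatter). Compound 4 `CCCN1[C@H](C)CN(c2cc3c(cc2OC)CCN3C(=O)c2ccc(-c3cccc(C)n3)c3ccccc23)C[C@@H]1C` differs from compound 3 by methyl in place of hydrogen on a saturated chain carbon, two bonds along the chain from an amine nitrogen in a ring. All three measured steps concern the substituent on the same amine nitrogen in a ring: a 1.3-fold higher number from compound 1 to compound 2 (0.10 log units; within the scatter), no change at the digits printed from compound 2 to compound 3 (within the scatter) and a 1.3-fold higher number from compound 1 to compound 3 (0.10 log units; within the scatter). Not one of them carries the number beyond the scatter, whether the group on that nitrogen is hydrogen, methyl or ethyl. Lengthening that group by one more carbon, from ethyl to propyl, is the same kind of change, so no step beyond the scatter is expected in this assay, in either direction. The step to compound 4 is expected to be a 1.0-fold higher number from compound 3 to compound 4 (0.01 log units; within the scatter). The estimate for compound 4 is 130 nM, with a range from 60 nM to 280 nM.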

Compound 4, inhibition constant: 158 nM
Beside the measured number, compound 4's estimate is 1.2-fold (0.08 log units) below it; measured number inside the range.
By their numbers in this assay, from the lowest: compounds 1, 2, 3 and 4 (each within the scatter of the next).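

In this assay, lengthening the group on the amine nitrogen in a ring from ethyl to propyl gives a 1.3-fold higher number from compound 3 to compound 4 (0.10 log units; within the scatter), and putting propyl in place of hydrogen on that nitrogen gives a 1.3-fold higher number from compound 2 to compound 4 (0.10 log units; within the scatter). The earlier compounds reached only ethyl at this position; with propyl the series now spans hydrogen, methyl, ethyl and propyl, and the step between the methyl and propyl compounds, a 1.6-fold higher number from compound 1 to compound 4 (0.20 log units; within the scatter), also stays inside the scatter, so that no group shown here separates from the others in this assay. Nothing measured alongside these numbers offers an account of how closely they sit together.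

As far as these compounds go, whether a longer chain such as butyl, a branched group such as isopropyl, or a chain ending in a hydroxyl group or a carboxylic acid on this nitrogen would carry the number beyond the scatter remains open. The compounds shown also carry numbers for this one receptor only, so how the same change reads on any other receptor cannot be told from them.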